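The compounds below may be only part of what the source reports. "The series", "measured", "known", "first", "only" and "open" are said of these compounds alone.

Among the compounds with values here, compound 2 `C[C@@H](NC(=O)c1cccc(Cl)c1)[C@H]1CC[C@@H](c2ccnc3ccc(F)cc32)CC1` carries a (3-chlorophenyl)carbonyl on its amine nitrogen, and in an assay on tissue (HeLa cells) for inhibition of Indoleamine 2,3-dioxygenase 1 (Homo sapiens), with stated times of 2 h and 18 h (on this read-out higher numbers stand for weaker inhibition and lower numbers for stronger inhibition), compound 2 gives 7 nM, the only number the set holds. Compound 1 `C[C@@H](NS(=O)(=O)c1ccc(Cl)cc1)[C@H]1CC[C@@H](c2ccnc3ccc(F)cc32)CC1`, which bears a (4-chlorophenyl)sulfonyl at the same nitrogen, reaches only a limit of the assay, > 1000 nM. Within the data shown here, the one measured step, an at least 140-fold lower number from compound 1 to compound 2 (2.15 log units; beyond the scatter), therefore rests on the limit of > 1000 nM in this assay, at which 1 of the 2 values shown sits, and concerns the exchange of sulfonyl for carbonyl and not the ring on it.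

Compound 3 `C[C@@H](NC(=O)C12CCC(Cl)(CC1)CC2)[C@H]1CC[C@@H](c2ccnc3ccc(F)cc32)CC1` differs from compound 2 by a group of 9 heavy atoms (8 carbon, 1 chlorine; 2 six-membered non-aromatic rings of carbon only) in place of a group of 7 heavy atoms (6 carbon, 1 chlorine; one six-membered aromatic ring of carbon only), on a carbonyl carbon. Among the measured compounds shown here, no measured step addresses a change of this kind, so the expectation for compound 3 in this assay leans on compound 2 alone, with its 7 nM, and on the fact that the amide linker is kept. The step from compound 2 to compound 3 is expected to be small and to run toward weaker inhibition, a 2.9-fold higher number from compound 2 to compound 3 (0.46 log units; beyond the scatter), as a saturated cage replaces the aromatic ring while the chlorine stays. Compound 3 is estimated at 20 nM, with a range from 5 nM to 80 nM.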

Compound 3, half-maximal inhibitory concentration: 24 nM
Beside the measured number, compound 3's estimate is 1.2-fold (0.08 log units) below it; measured number inside the range.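

In this assay, the exchange of the 3-chlorophenyl for the group with 2 six-membered non-aromatic rings of carbon only, on a carbonyl carbon whose other neighbour is an amide-type nitrogen, gives a 3.4-fold higher number from compound 2 to compound 3 (0.54 log units; beyond the scatter). The earlier step changed the linker together with the group it carries, whereas this one keeps the carbonyl and changes only the group on it, and it shows that this position tolerates the loss of the aromatic ring at a modest cost: compound 3, with no aromatic ring at this place, still gives 24 nM in this assay. The compounds shown offer no measurement that bears on why the number rises by this amount.

As far as these compounds go, both compound 2 and compound 3 carry a chlorine, so what that atom contributes at this position stays open, as does the effect of replacing it with a hydrogen, a nitrile or a methoxy group. From the compounds shown here alone, it also stays open how this position would respond to a pyridine ring, to a longer open carbon chain, or to an amine or a carboxylic acid on the group attached to the carbonyl carbon.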